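Isopropyl in Place of Methyl on the Ring Amine

The compounds below may be only part of what the source reports. "The series", "measured", "known", "first", "only" and "open" are said of these compounds alone.

In an assay on HEK293 cells for displacement of a labelled ligand from 5-hydroxytryptamine receptor 7 (Rattus norvegicus), with a stated time of 60 min (a higher number here means a weaker inhibitor, a lower number a stronger inhibitor), the measured compounds are:
compound 2 `CN1CCc2c(c(-c3ccc(Cl)cc3)cn2Cc2ccccc2)C1` – 36 nM
compound 1 `Clc1ccc(Cn2cc(-c3ccccc3)c3c2CCNC3)cc1` – 753 nM

Compound 2 has the lowest of the two numbers; compound 1 sits a step away that lies beyond the scatter. Compound 3 `CC(C)N1CCc2c(c(-c3ccc(Cl)cc3)cn2Cc2ccccc2)C1` is not yet measured. It differs from compound 2 by isopropyl in place of methyl on an amine nitrogen in a ring. Among the measured compounds shown here, no measured pair shows this kind of change, so the step from compound 2 to compound 3 is expected to be small, most likely toward a higher number but possibly within the scatter, which is what a 1.8-fold higher number from compound 2 to compound 3 (0.26 log units; within the scatter) expresses. Compound 3 is estimated at 65 nM in this assay, in the range 15 nM to 280 nM.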

Compound 3, inhibition constant: 370 nM
Compound 3: the middle estimate sits 5.7-fold (0.76 log units) below what was measured; the whole stated range lies below it.
By their numbers in this assay, from the lowest: compound 2; then compound 3; then compound 1.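

In this assay the amine nitrogen in a ring proves to be a position where this change counts: isopropyl in place of methyl gives a large step (a 10-fold higher number from compound 2 to compound 3 (1.01 log units; beyond the scatter)). Among the compounds shown here, the earlier compounds held no pair differing in this one place, so this is the first reading of any change there. No evidence shown bears on the cause of this step. From the compounds shown here alone, whether ethyl or cyclopropyl on that nitrogen would stay nearer compound 2 or compound 3 remains open, as does the result of a longer chain there.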